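Chloro on the distal ring of a dienone series

The source may hold more compounds than are shown below. What is called first, only, known or untested is meant among the compounds shown, and "the series" means these compounds.

Three compounds of the shared core have been run through an in vitro assay on cells for inhibition of Amine oxidase [flavin-containing] A (Homo sapiens), read by Amplex Red, with a stated time of 15 min, tested at 100 uM; a lower number here means less inhibition, a higher number more inhibition at the concentration tested (going by the name of the read-out). For the measured compounds named here, compound 1 `COc1ccc(/C=C/C=C/C(=O)c2ccccc2O)cc1OC` gives 40%, the only number in the set so far. Compound 3 `O=C(/C=C/C=C/c1ccccc1)c1ccccc1O` is reported as "not active" (no number reported), with no figure attached. Compound 2 `O=C(/C=C/C=C/c1ccccc1)c1cc(Cl)ccc1O`, which carries a chloro on the hydroxyphenyl side, is likewise reported as "not active" (no number reported), again without a figure. Compound 2 therefore stands without a number of its own; it sits alongside compound 3 as a second entry of that kind, and the only numeric anchor in the series belongs to compound 1.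

Compound 4 `O=C(/C=C/C=C/c1ccc(Cl)cc1)c1cc(Cl)ccc1O` is the next compound to be measured in this assay. The change from compound 2 is chloro in place of hydrogen on an aromatic carbon. Going by the values given here, no measured pair in the set isolates this change, so its effect is not known from the data. Given that compound 2 and compound 3 are both reported as inactive, the expectation is for no step beyond the scatter, in either direction, with any small shift most likely staying at the low end of inhibition. For compound 4 the expected inhibition in this assay is estimated at 10%, within a range of 0% to 30%.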

Compound 4, a percentage reported as inhibition, at one concentration (the size of the read-out at that concentration, not a potency): "not active" (no number reported)
No number was reported for compound 4; no gap can be computed for the estimate.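

Compound 2 and compound 4 are both reported as not active, with no number for either, so no step can be read for the change from phenyl to 4-chlorophenyl. The compounds shown leave open whether this change alters inhibition where a measurable value exists. No available evidence bears on this result.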